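The source may hold more compounds than are shown below. What is called first, only, known or untested is meant among the compounds shown, and "the series" means these compounds.

Working notes on the series. Within the data shown here, the three measured members share one core and differ only in the aryl on the carbon with a double bond to nitrogen: compound 1 `COc1ccc(/C=N/NC(=O)Nc2ccc(Oc3ccnc(-c4nncn4CCN(C)C)c3)c(F)c2)c(OC)c1OC`, compound 2 `CN(C)CCn1cnnc1-c1cc(Oc2ccc(NC(=O)N/N=C/c3ccccc3)cc2F)ccn1` and compound 3 `CN(C)CCn1cnnc1-c1cc(Oc2ccc(NC(=O)N/N=C/c3ccc(F)cc3F)cc2F)ccn1`. In a functional assay on NCI-H460 cells (Homo sapiens) for cytotoxicity, read by MTT assay, with a stated time of 72 h (a lower number here means a stronger inhibitor, a higher number a weaker inhibitor), compound 1 gives 1790 nM, compound 2 gives 1780 nM and compound 3 gives 1930 nM. Compound 2 holds the lowest of the three numbers, but the steps of a 1.0-fold lower number from compound 1 to compound 2 (0.00 log units; within the scatter) and a 1.1-fold higher number from compound 2 to compound 3 (0.04 log units; within the scatter) are both within the scatter, as is a 1.1-fold higher number from compound 1 to compound 3 (0.03 log units; within the scatter), so no order among the three is established.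

Compound 4 `Cn1cnnc1-c1cc(Oc2ccc(NC(=O)N/N=C/c3ccccc3)cc2F)ccn1` is the unmeasured member. It differs from compound 2 by hydrogen in place of (dimethylamino)methyl on a saturated chain carbon bound to an aromatic nitrogen. Among the measured compounds shown here, none of the measured steps touches this part of the molecule; all three vary the aryl on the carbon with a double bond to nitrogen and were flat. For the measured compounds named here, the step from compound 2 to compound 4 therefore rests on no measured precedent, and the expectation is no change beyond the scatter, with a wide range to cover the untested site. The estimate for compound 4 in this assay is 2500 nM, expected between 900 nM and 7000 nM. The expected step is a 1.4-fold higher number from compound 2 to compound 4 (0.15 log units; within the scatter).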

Compound 4, half-maximal inhibitory concentration: 15700 nM
Compound 4: the middle estimate sits 6.3-fold (0.80 log units) below what was measured, and the stated range ends below it.
By their numbers in this assay, from the lowest: compounds 2, 1 and 3 (each within the scatter of the next); then compound 4.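

Unlike the aryl on the carbon with a double bond to nitrogen, where every step was flat, this position matters in this assay: replacing 2-(dimethylamino)ethyl with methyl gives an 8.8-fold higher number from compound 2 to compound 4 (0.95 log units; beyond the scatter) and is the only step in the series beyond the scatter. The result rests on a single pair with phenyl as the aryl, so it shows the position's sensitivity to this change, not a trend along a chain. No evidence is available that bears on the reason for the step.

The compounds shown do not separate the dimethylamino group from the chain that carries it; a plain ethyl or a 2-hydroxyethyl in place of 2-(dimethylamino)ethyl would do so. Also open, going by these compounds, is whether the step holds with 2,4-difluorophenyl or 2,3,4-trimethoxyphenyl as the aryl.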